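The source may report more compounds than this note shows. Statements on the series, on what has been measured and on what is new or still open speak of the compounds shown alone.

Measured so far in a functional assay on SGC-7901 cells (Homo sapiens) for antiproliferative activity, read by sulforhodamine B assay, with a stated time of 72 h; a higher number here means a weaker inhibitor, a lower number a stronger inhibitor: compound 1 `NC(=S)N/N=C/c1ccc2ccccc2n1` gives 32700 nM. Compound 2 `S=C(N/N=C/c1ccc2ccccc2n1)Nc1ccccc1Br` gives > 100000 nM, which is a limit of the assay and not a number, so compound 2 stands at the limit of > 100000 nM in this assay, at which 1 of the 2 values shown sits.

Compound 3 `COc1ccc(NC(=S)N/N=C/c2ccc3ccccc3n2)cc1` differs from compound 2 by 4-methoxyphenyl in place of 2-bromophenyl on an amide-type nitrogen. Among the compounds with values here, the one measured step that bears on an aryl group at this nitrogen is an at least 3.0-fold higher number from compound 1 to compound 2 (0.48 log units; beyond the scatter), and since it ran into the limit, no firm size for a swap between aryl groups can be drawn from it. Compound 3 is expected to sit near the same weak level in this assay, estimated at 60000 nM, within 15000 nM to 150000 nM. The expected step is an at least 1.6-fold lower number from compound 2 to compound 3 (0.22 log units; that floor lies within the scatter).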

Compound 3, half-maximal inhibitory concentration: 89600 nM
Compound 3: the middle estimate sits 1.5-fold (0.17 log units) below what was measured, within the range that was stated.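

With 4-methoxyphenyl in place of hydrogen on the amide-type nitrogen, this assay shows a 2.7-fold higher number from compound 1 to compound 3 (0.44 log units; beyond the scatter), so an aryl group at this nitrogen now has a measured loss and not only a floor. Between the two aryl groups the data give an at least 1.1-fold lower number from compound 2 to compound 3 (0.04 log units; that floor lies within the scatter), which does not separate 4-methoxyphenyl from 2-bromophenyl. The entry for compound 2 is a limit of the assay and not a number: the limit of > 100000 nM in this assay, at which 1 of the 3 values shown sits.

Open, going by these compounds, is whether a methyl or benzyl group on this nitrogen stays nearer compound 1. Also open, on these data alone, is whether an aryl ring carrying an amine or a carboxylic acid behaves differently.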